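Amino for Nitro on the Sulfonyl Aryl Ring

The source may report more compounds than this note shows. Statements on the series, on what has been measured and on what is new or still open speak of the compounds shown alone.

Compound 1 `Cn1c(=O)c(S(=O)(=O)c2ccc(F)cc2[N+](=O)[O-])cc2cnc(Nc3ccc4[nH]ccc4c3)nc21` was tested in a functional assay on K562 cells (Homo sapiens) for inhibition, read by trypan blue exclusion, with a stated time of 72 h (a higher number here means a weaker inhibitor, a lower number a stronger inhibitor), where compound 1 gives 900 nM. Among the three measured compounds it holds the second highest number. Compound 2 `Cn1c(=O)c(S(=O)(=O)c2ccc(OC(=O)CCCCC3SCC4NC(=O)NC43)cc2)cc2cnc(Nc3ccc4[nH]ccc4c3)nc21` gives 600 nM in this assay, a value within the scatter of compound 1, so the two cannot be ordered. Compound 3 `Cc1ccc(S(=O)(=O)c2cc3cnc(Nc4cnc5[nH]ccc5c4)nc3n(C)c2=O)cc1` gives 15000 nM, a number well beyond the scatter above compound 1. The unmeasured compound 4 `Cn1c(=O)c(S(=O)(=O)c2ccc(N)cc2F)cc2cnc(Nc3ccc4[nH]ccc4c3)nc21` differs from compound 1 in one place: 4-amino-2-fluorophenyl in place of 4-fluoro-2-nitrophenyl on a sulfonyl sulfur. Going by the values given here, no measured pair shows this change, so the direction is uncertain; the expected step is small, a 1.3-fold lower number from compound 1 to compound 4 (0.11 log units; within the scatter), not clearly beyond the scatter. Compound 4 is therefore estimated at 700 nM, within a range from 200 nM to 3000 nM.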

Compound 4, half-maximal inhibitory concentration: 1500 nM
For compound 4 the middle estimate is 2.1-fold (0.33 log units) below the measured one; the range from low to high includes it.
By their numbers in this assay, from the lowest: compounds 2, 1 and 4 (each within the scatter of the next, the first and the last beyond it); then compound 3.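

In this assay, the exchange of 4-fluoro-2-nitrophenyl for 4-amino-2-fluorophenyl on the sulfonyl sulfur gives a 1.7-fold higher number from compound 1 to compound 4 (0.22 log units; within the scatter). This first one-place comparison at this position therefore does not separate the two aryl groups: the nitro group can leave and an amino group enter without a change beyond the scatter. Nothing available explains the result.

As far as these compounds go, because the two aryl groups differ in more than one substituent, the contribution of the amino group alone stays open. Also open, from the compounds shown here alone, is how an acetamide or a carboxylic acid on this phenyl ring would read in this assay.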